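Cytotoxicity of Four Related Compounds on Skin Cells

The source may report more compounds than this note shows. Statements on the series, on what has been measured and on what is new or still open speak of the compounds shown alone.

Compound 1 `Fc1ccc(-c2nn(-c3ccccc3)cc2-c2nc3cc(Br)ccc3[nH]2)cc1` was tested in an ADME assay on HaCaT cells (Homo sapiens) for cytotoxicity, read by MTT assay, with a stated time of 48 h (on this read-out lower numbers stand for stronger inhibition and higher numbers for weaker inhibition), where compound 1 gives 21800 nM. Compound 2 `COc1ccc2[nH]c(-c3cn(-c4ccccc4)nc3-c3ccc(F)cc3)nc2c1` carries the change methoxy in place of bromo on an aromatic carbon on the shared core. In this assay compound 2 reaches only a limit of the assay, > 50000 nM. This change made a step of an at least 2.2-fold higher number from compound 1 to compound 2 (0.36 log units; beyond the scatter). Compound 3 `Clc1ccc(-c2nn(-c3ccccc3)cc2-c2nc3cc(Br)ccc3[nH]2)cc1` differs from compound 1 by chloro in place of fluoro on an aromatic carbon, so the two cores are not identical. In this assay compound 3 also stops at a limit, > 50000 nM. Its step from compound 1 reads an at least 2.2-fold higher number from compound 1 to compound 3 (0.36 log units; beyond the scatter). Both steps can only be given as minimum sizes because of the limit of > 50000 nM in this assay, at which 2 of the 3 values shown sit.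

Compound 4 `COc1ccc2[nH]c(-c3cn(-c4ccccc4)nc3-c3ccc(Cl)cc3)nc2c1` has not yet been measured in this assay. It differs from compound 3 by methoxy in place of bromo on an aromatic carbon, the same change, at the same place, that turned compound 1 into compound 2. Since compound 3 already gives > 50000 nM and the earlier change raised the number by an at least 2.2-fold higher number from compound 1 to compound 2 (0.36 log units; beyond the scatter), compound 4 is expected to stay at or beyond the limit, with an estimated 90000 nM. For compound 4 the expected step is therefore a step that the limit leaves unreadable from compound 3 to compound 4.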

Compound 4, half-maximal inhibitory concentration: > 50000 nM
Compound 4 was reported as a limit; the forecaster's own chance of this, stated with the estimate: 85%; the middle value lies beyond the limit too.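

In this assay compound 4 gives > 50000 nM, which is a limit of the assay. No new step can be read from compound 4 to compound 2 or compound 3, because all three stop at the same limit: the limit of > 50000 nM in this assay, at which 3 of the 4 values shown sit.

The compounds shown leave open how far compound 2, compound 3 and compound 4 truly differ from one another.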